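A few compounds are considered here, and "the series" means these few. Any claim that something is new, unique, unknown or untested is made for them only; others in the source may bear on it.

In a functional assay on HeLa cells (Homo sapiens) for inhibition, read by CCK-8 assay, with a stated time of 48 h (a higher number here means a weaker inhibitor, a lower number a stronger inhibitor), compound 1 `O=C1CSC(N2N=C(c3ccc(Cl)cc3)CC2c2cccc3ccccc23)=N1` gives 8840 nM and compound 3 `Clc1ccc(C2=NN(C3=NC(c4ccccc4)CS3)C(c3cccc4ccccc34)C2)cc1` gives 9940 nM, which lie within the scatter of each other. Compound 2 `Cc1ccc(C2=NN(C3=NC(=O)CS3)C(c3ccc4ccccc4c3)C2)cc1C` gives 860 nM, a lower number beyond the scatter. Compound 4 `Cc1ccc(C2=NN(C3=NC(=O)CS3)C(c3cccc4ccccc34)C2)cc1` differs from compound 1 in one place: methyl in place of chloro on an aromatic carbon. For the measured compounds named here, the only measured step, a 1.1-fold higher number from compound 1 to compound 3 (0.05 log units; within the scatter), changes another part of the molecule and does not test this swap. Compound 2 also bears methyl, but it differs from compound 1 in more than one place, so it offers only a weak hint of a lower number in this assay. A modest drop is therefore expected, with the estimated step being a 2.2-fold lower number from compound 1 to compound 4 (0.34 log units; beyond the scatter). For compound 4 the expected value is 4000 nM, with an estimated range of 1200 nM to 11000 nM.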

Compound 4, half-maximal inhibitory concentration: 3210 nM
Compound 4: the middle estimate sits 1.2-fold (0.10 log units) above what was measured; the range from low to high includes it.
By their numbers in this assay, from the lowest: compound 2; then compound 4; then compounds 1 and 3 (each within the scatter of the next).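

In this assay, for the compounds shown here, changing 4-chlorophenyl to 4-methylphenyl gives a 2.8-fold lower number from compound 1 to compound 4 (0.44 log units; beyond the scatter) and is the first direct test of this swap. It shows that replacing one heavy atom on this aromatic carbon, para to a large group, can move the number beyond the scatter. Nothing available bears on the reason for this drop. From the compounds shown here alone, whether a methoxy group, an amine or a carboxylic acid on this carbon would lower the number further remains open. So does whether this swap would give a similar step on the core of compound 3 .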